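The source may hold more compounds than are shown below. What is called first, only, known or untested is meant among the compounds shown, and "the series" means these compounds.

Working notes on the series built from compound 1, `C=C1C[C@]23C[C@@]1(O)CC[C@H]2c1ccc(O)c(C)c1[C@@H]3Cn1cc(-c2ccccn2)nn1`, compound 2, `C=C1C[C@]23C[C@@]1(O)CC[C@H]2c1ccc(O)c(C)c1[C@@H]3Cn1cc(-c2ccc(C(F)(F)F)cc2)nn1`, and compound 3, `C=C1C[C@]23C[C@@]1(O)CC[C@H]2c1ccc(O)c(C)c1[C@@H]3Cn1cc(-c2ccccc2)nn1`, three compounds on one shared core that differ only in the aromatic group carried at the far end. In a functional assay on MCF7 cells (Homo sapiens) for cytotoxicity, read by MTT assay, with a stated time of 4 days (on this read-out higher numbers stand for weaker inhibition and lower numbers for stronger inhibition), compound 1 gives only a limit of > 20000 nM. In this assay compound 3 also gives only a limit of > 20000 nM. Compound 2 gives 12400 nM in this assay. The step of an at least 1.6-fold higher number from compound 2 to compound 3 (0.20 log units; that floor lies within the scatter) is thus read against a limit, and the limit of > 20000 nM in this assay, at which 2 of the 3 values shown sit, caps what the steps from compound 1 can show; an at least 1.6-fold lower number from compound 1 to compound 2 (0.20 log units; that floor lies within the scatter) is likewise small. Compound 4, `C=C1C[C@]23C[C@@]1(O)CC[C@H]2c1ccc(O)c(C)c1[C@@H]3Cn1cc(-c2ccc(OC)cc2)nn1`, is not yet measured and differs from compound 3 by methoxy in place of hydrogen on an aromatic carbon. Within the data shown here, the only comparable step, an at least 1.6-fold higher number from compound 2 to compound 3 (0.20 log units; that floor lies within the scatter), shows nothing beyond the scatter. Compound 4 is therefore expected near 20000 nM, between 8000 nM and 50000 nM, meaning an expected a number no higher from compound 3 to compound 4 (the limit leaves the size open).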

Compound 4, half-maximal inhibitory concentration: > 20000 nM
Compound 4: only a limit was reported; the forecaster's own chance of this, stated with the estimate: 55%; the middle value lies on the limit itself.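

Methoxy on the six-membered aromatic ring of carbon only, para to a large group, gives no measurable number: compound 4 reports only a limit. Among these compounds, the one readable new step, an at least 1.6-fold higher number from compound 2 to compound 4 (0.20 log units; that floor lies within the scatter), therefore separates neither compound from the other, and the steps from compound 1 and compound 3 to compound 4 cannot be read. Readings for this change stay capped in this assay: the limit of > 20000 nM in this assay, at which 3 of the 4 values shown sit.

As far as these compounds go, whether an amine or a carboxylic acid at this place would give a number stays open. So does any difference among compound 1, compound 3 and compound 4.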